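A few compounds are considered here, and "the series" means these few. Any claim that something is new, unique, unknown or untested is made for them only; others in the source may bear on it.

Measured compounds:
compound 1, `O=S(=O)(NC[C@H](O)CN1CCCC1)c1cccc2ccccc12`, in an assay on HEK293 cells for inhibition of sodium- and chloride-dependent glycine transporter 1 (Homo sapiens) (on this read-out higher numbers stand for weaker inhibition and lower numbers for stronger inhibition), compound 1 gives 3160 nM
compound 2, `O=S(=O)(NC[C@H](O)CN1CCCC1C1CC1)c1cccc2ccccc12`, in this assay compound 2 gives 501 nM; 1580 nM (2 entries)

Going by the values given here, compound 1 holds the only single number in this assay; the other measured compound, compound 2, carries several entries, (the several entries of compound 2 in this assay, 501 nM; 1580 nM (2 entries)), which spread across each other. No change between the two measured compounds is tallied as a step, so their values are read simply as they stand.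

Compound 3, `O=S(=O)(NC[C@H](O)CN1CCCCC1)c1cccc2ccccc12`, has not yet been measured. It differs from compound 1 in one place: piperidin-1-yl in place of pyrrolidin-1-yl on a saturated chain carbon, two bonds along the chain from an oxygen on a saturated carbon. The change is a ring expansion by one saturated ring atom with no change in donors, acceptors or charge, so any shift is expected to be modest. Compound 3 is estimated at 1800 nM in this assay, within a range of 500 nM to 6000 nM. The step from compound 1 to compound 3 is thus expected to be a 1.8-fold lower number from compound 1 to compound 3 (0.24 log units; within the scatter), a small gain that may not clear the scatter.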

Compound 3, half-maximal inhibitory concentration: 3160 nM
The estimate for compound 3 lay 1.8-fold (0.24 log units) below the measured number, within the range that was stated.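

Going by these compounds alone, putting piperidin-1-yl in place of pyrrolidin-1-yl, on a saturated chain carbon, two bonds along the chain from an oxygen on a saturated carbon, gives no change at the digits printed from compound 1 to compound 3 (within the scatter) in this assay as the first one-place comparison at this position. The result shows that this ring can take one more saturated ring atom, with the same counts of donors and acceptors and no net charge, without any readable movement in the inhibition value. No measurement shown gives a cause for this flat step.

As far as these compounds go, it remains open how this position responds to groups of a different kind, such as morpholin-4-yl, a diethylamino group or a primary amine. From the compounds shown here alone, it is also open whether a ring larger than piperidin-1-yl, such as azepan-1-yl, would leave the value just as flat.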